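Benzyl ring substitution in the pyridinone series: compound 3 to compound 4

The compounds below may be only part of what the source reports. "The series", "measured", "known", "first", "only" and "open" are said of these compounds alone.

Compound 3 `O=c1ccc(-c2ccc3cn[nH]c3c2)cn1Cc1cccc(F)c1` stands second highest of the three numbers measured in an assay for inhibition of MAP kinase-interacting serine/threonine-protein kinase 1 (Homo sapiens), read by luminescence and ADP-Glo, with a stated time of 2 h (on this read-out lower numbers stand for stronger inhibition and higher numbers for weaker inhibition), at 74 nM. Compound 2 `O=c1ccc(-c2ccc3cn[nH]c3c2)cn1Cc1cccc(Cl)c1` gives 37 nM, and compound 1 `O=c1ccc(-c2ccc3cn[nH]c3c2)cn1Cc1ccccc1C(F)(F)F` gives 133 nM; both neighbours sit within the scatter of compound 3. Among the measured compounds shown here, the only step measured, a 2.0-fold higher number from compound 2 to compound 3 (0.30 log units; within the scatter), concerns a halogen swap at the same place and does not directly bear on the change now considered. Compound 4 `O=c1ccc(-c2ccc3cn[nH]c3c2)cn1Cc1ccccc1F` differs from compound 3 by 2-fluorophenyl in place of 3-fluorophenyl on a saturated chain carbon bound to an aromatic nitrogen. Compound 1, with its own group on a 2-substituted benzyl, shows no value beyond the scatter of compound 3, so no step beyond the scatter is expected here. For compound 4 the expected step is a 1.4-fold higher number from compound 3 to compound 4 (0.13 log units; within the scatter), giving an estimate of 100 nM with a range from 45 nM to 220 nM in this assay.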

Compound 4, half-maximal inhibitory concentration: 47 nM
Compound 4: middle estimate off by 2.1-fold (0.33 log units), on the high side; the measured number falls inside the stated range.
By their numbers in this assay, from the lowest: compounds 2, 4, 3 and 1 (each within the scatter of the next, the first and the last beyond it).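

In this assay, moving the fluoro group gives a 1.6-fold lower number from compound 3 to compound 4 (0.20 log units; within the scatter), so 2-fluorobenzyl and 3-fluorobenzyl are not told apart on this saturated chain carbon bound to an aromatic nitrogen. The step from the 3-chlorophenyl group to the 2-fluorophenyl group, a 1.3-fold higher number from compound 2 to compound 4 (0.10 log units; within the scatter), also stays within the scatter. Fluoro in place of trifluoromethyl gives a 2.8-fold lower number from compound 1 to compound 4 (0.45 log units; beyond the scatter), so for this pair changing the group registers as a modest step, where moving fluoro did not.

No evidence on hand accounts for these steps. Going by these compounds, whether an amine or a carboxylic acid on the benzyl ring, or a longer chain in place of the benzyl carbon, would shift the number remains open.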